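The source may report more compounds than this note shows. Statements on the series, on what has been measured and on what is new or still open speak of the compounds shown alone.

Measured in a functional assay on A549 cells (Homo sapiens) for antiproliferative activity, read by MTT assay, with a stated time of 48 h; on this read-out lower numbers stand for stronger inhibition and higher numbers for weaker inhibition:
- Compound 1 `COc1cc(-c2nnc3c(OC(C)C)cc(-c4ccc5[nH]ccc5c4)cn23)cc(OC)c1OC`: 1250 nM
- Compound 2 `COc1cc(-c2nnc3c(OC4COC4)cc(-c4ccc5[nH]ccc5c4)cn23)cc(OC)c1OC`: 9810 nM
- Compound 3 `COc1cc(-c2nnc3c(OC4CC4)cc(-c4ccc5[nH]ccc5c4)cn23)cc(OC)c1OC`: 198 nM

Of these three, compound 2 gives the highest number, at 9810 nM, which makes it the weakest inhibitor in this assay. Its steps to both other compounds lie beyond the scatter.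

Compound 4 `COc1cc(-c2nnc3c(OC4COC4)cc(-c4ccc5c(ccn5C)c4)cn23)cc(OC)c1OC` keeps the oxetan-3-yl group of compound 2 and differs in one place: methyl in place of hydrogen on an aromatic nitrogen. Its 1H-indol-5-yl becomes 1-methyl-1H-indol-5-yl, with methyl in place of hydrogen on an aromatic nitrogen.

For the measured compounds named here, no measured step touches that nitrogen. All three change the group on the oxygen instead: a 7.8-fold higher number from compound 1 to compound 2 (0.89 log units; beyond the scatter), a 6.3-fold lower number from compound 1 to compound 3 (0.80 log units; beyond the scatter) and a 50-fold lower number from compound 2 to compound 3 (1.70 log units; beyond the scatter). They show that a small change elsewhere on these molecules can move the number a long way, but they say nothing about the direction of this new change. The data therefore support no firm prediction of a shift, only a wide range around the value of compound 2, and no step beyond the scatter is expected.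

The expected step is a 1.4-fold lower number from compound 2 to compound 4 (0.15 log units; within the scatter). For compound 4 the estimated value is 7000 nM, within an expected range of 2000 nM to 25000 nM.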

Compound 4, half-maximal inhibitory concentration: 516 nM
Beside the measured number, compound 4's estimate is 14-fold (1.13 log units) above it; the measured number lies below the stated range.
By their numbers in this assay, from the lowest: compound 3; then compound 4; then compound 1; then compound 2.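

Placing methyl in place of hydrogen on the aromatic nitrogen of the 1H-indol-5-yl group gives a 19-fold lower number from compound 2 to compound 4 (1.28 log units; beyond the scatter) in this assay, a large step beyond the scatter. For the compounds shown here, all the earlier steps changed the group on the oxygen, so this is the first sign that the nitrogen is also a position where a small change can move the number a long way, and in this pair the move is towards stronger inhibition; it also shows that the oxetan-3-yl group on the oxygen does not by itself keep the number high. Nothing available explains why this methyl has such an effect, so the step stands as an observation without a known cause.

The compounds shown leave open whether the same change would lower the number by a similar amount with isopropyl or cyclopropyl on the oxygen, since the step is known only with oxetan-3-yl there. They also leave open how the number would respond to other groups on this nitrogen, such as an ethyl group, a longer chain or a chain ending in an amine.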